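The source may hold more compounds than are shown below. What is called first, only, known or untested is meant among the compounds shown, and "the series" means these compounds.

Working notes on the series.

Compound 1 `CN(Cc1ccc(S(C)(=O)=O)cc1)C1CCN(CCCc2c[nH]c3ccc(-n4cnnc4)cc23)CC1` is tested in an assay on CHO cells for displacement of a labelled ligand from 5-hydroxytryptamine receptor 1D (Homo sapiens) (a lower number here means a stronger inhibitor, a higher number a weaker inhibitor), where compound 1 gives 18 nM. Among the compounds with values here, this is the higher of the two numbers measured so far. The other measured member is compound 2 `CC(=O)Nc1ccc(CNC2CCN(CCCc3c[nH]c4ccc(-n5cnnc5)cc34)CC2)cc1`, which in this assay gives 3 nM; compound 2 differs from compound 1 in more than one place, so the two values can only be set side by side, and they show compound 2 sitting well below compound 1, beyond the scatter.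

The next compound, compound 3 `CN(Cc1cccs1)C1CCN(CCCc2c[nH]c3ccc(-n4cnnc4)cc23)CC1`, is drawn from compound 1 by a single change: thiophen-2-yl in place of 4-(methylsulfonyl)phenyl on a saturated chain carbon bound to an amine nitrogen. The group that leaves is the larger one, with two hydrogen-bond acceptors; the group that enters keeps one acceptor and one aromatic ring, now five-membered with one hetero atom.

Within the data shown here, no measured pair in this set shows this change, so the size of the step rests on the two values alone. A modest step downward, within or just beyond the scatter, is expected, a 1.5-fold lower number from compound 1 to compound 3 (0.18 log units; within the scatter). Compound 3 is estimated to give 12 nM in this assay, with a range from 3 nM to 45 nM.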

Compound 3, half-maximal inhibitory concentration: 4.3 nM
Compound 3: the middle estimate sits 2.8-fold (0.45 log units) above what was measured, and the stated range covers the measured number.
By their numbers in this assay, from the lowest: compounds 2 and 3 (each within the scatter of the next); then compound 1.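

Within the data shown here, compound 3 gives the first comparison that differs in one place, and in this assay it reads as a 4.2-fold lower number from compound 1 to compound 3 (0.62 log units; beyond the scatter). On a saturated chain carbon bound to an amine nitrogen, the 4-(methylsulfonyl)phenyl group is therefore not needed to hold a low number, since the smaller thiophen-2-yl, with its five-membered ring and without the methylsulfonyl group, gives a number lower by more than the scatter. Nothing measured in the series accounts for the size or direction of this step.

The swap alters the ring and removes the methylsulfonyl group together, so these compounds cannot say which of the two carries the step; a plain phenyl on the same carbon would separate them, and a furan-2-yl would test whether the sulfur of the thiophene matters. From the compounds shown here alone, the role of the methyl on the amine nitrogen also stays open, as compound 2 differs from both compound 1 and compound 3 in more than one place and so offers no clean reading of that group.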